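The compounds below may be only part of what the source reports. "The series", "measured", "known", "first", "only" and "open" are said of these compounds alone.

In a functional assay on MM1.S cells (Homo sapiens) for cytotoxicity, read by MTT assay, with a stated time of 48 h (a higher number here means a weaker inhibitor, a lower number a stronger inhibitor), compound 1 (`C#CCOC(=O)NN=C1C(Cl)=C(Cl)C(Cl)=C1Cl`) stands at "not determined" (no result reported), which leaves no number to start from. The only figure at hand comes from compound 2 (`Fc1cccc(NN=C2C(Cl)=C(Cl)C(Cl)=C2Cl)c1`), which gives 1500 nM. Compound 3 (`O=C(NN=C1C(Cl)=C(Cl)C(Cl)=C1Cl)c1ccccc1`) carries one change from compound 1: phenyl in place of propargyloxy on a carbonyl carbon. Among the compounds with values here, no measured step shows what such a swap does. Within the data shown here, with compound 2 at 1500 nM as the sole guide, compound 3 is expected to show no step beyond the scatter from that level in this assay, in either direction. The estimated value for compound 3 is 1500 nM, with an expected range of 500 nM to 5000 nM.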

Compound 3, half-maximal inhibitory concentration: 800 nM
For compound 3 the middle estimate is 1.9-fold (0.27 log units) above the measured one; measured number inside the range.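

In this assay, within the data shown here, compound 3 gives 800 nM, but compound 1 has no single number here, so no step between compound 1 and compound 3 can be read. As far as these compounds go, what phenyl in place of propargyloxy does in this assay stays open, and no supporting evidence bears on the result.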